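Changing the Group Attached to the Carbonyl Carbon

The source may report more compounds than this note shows. Statements on the series, on what has been measured and on what is new or still open speak of the compounds shown alone.

Of the compounds shown here, three of one family have been measured so far. Compound 1 `O=C(NCCCCC(c1ccc(F)cc1)c1ccc(F)cc1)Nc1ccc(C(F)(F)F)cc1` was tested in a functional assay on MDA-MB-231 cells (Homo sapiens) for cytotoxicity, read by MTT assay, with a stated time of 48 h (a lower number here means a stronger inhibitor, a higher number a weaker inhibitor), and in it compound 1 gives 2780 nM. Compound 2 `COc1ccc(C(CCCCNC(=O)Nc2ccc(Cl)c(C(F)(F)F)c2)c2ccc(OC)cc2)cc1` gives 3300 nM in this assay, and compound 3 `O=C(CCCCC(c1ccc(F)cc1)c1ccc(F)cc1)Nc1ccc(Cl)c(C(F)(F)F)c1` gives 11400 nM. Compound 1 therefore has the lowest number of the three: compound 2 lies within the usual scatter of it, while compound 3 lies beyond the scatter, on the weaker side.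

Compound 4 `O=C(NCCCCC(c1ccc(F)cc1)c1ccc(F)cc1)c1ccc(Cl)c(C(F)(F)F)c1` has not yet been measured. It differs from compound 1 in a single place, namely (4-chloro-3-(trifluoromethyl)phenyl in place of (4-(trifluoromethyl)phenyl)amino on a carbonyl carbon). The group that leaves carries the only hydrogen-bond donor of that part of the molecule, and the group that enters is a ring carrying chlorine and trifluoromethyl, with no donor at all.

Among the compounds with values here, no step between two measured compounds is available, so the size of the expected change rests on the values alone. Because compound 3 gives 11400 nM, a compound without the amino link at its carbonyl carbon appears to sit on the weaker side, and the step from compound 1 to compound 4 is expected to be a modest one toward a weaker inhibitor, a 2.2-fold higher number from compound 1 to compound 4 (0.33 log units; beyond the scatter). Compound 4 is accordingly estimated at 6000 nM, with a likely range from 2500 nM to 15000 nM.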

Compound 4, half-maximal inhibitory concentration: 11700 nM
The estimate for compound 4 lay 2.0-fold (0.29 log units) below the measured number; the range from low to high includes it.
By their numbers in this assay, from the lowest: compounds 1 and 2 (each within the scatter of the next); then compounds 3 and 4 (each within the scatter of the next).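

In this assay, within the data shown here, placing 4-chloro-3-(trifluoromethyl)phenyl in place of (4-(trifluoromethyl)phenyl)amino on a carbonyl carbon gives a 4.2-fold higher number from compound 1 to compound 4 (0.62 log units; beyond the scatter), the first measured step in this family, and it shows that the group at this position matters for the read-out. The two groups have the same heavy-atom count and each holds one six-membered aromatic ring, so the step is not tied to a difference in those counts; what differs is that the nitrogen and its hydrogen-bond donor leave and a chlorine enters. No measurement is available that gives a reason for this weakening.

This single change alters two things at once, the amino link and the pattern on the ring, so the compounds shown cannot say how much of the step belongs to each. A 4-(trifluoromethyl)phenyl group set directly on the carbonyl carbon, or an oxygen or methylene link in place of the nitrogen, would be the kind of compound that could separate the two.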